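Naphthalenyl in Place of Methoxyphenyl on the Ring Nitrogen

A few compounds are considered here, and "the series" means these few. Any claim that something is new, unique, unknown or untested is made for them only; others in the source may bear on it.

Compound 1, `COc1ccccc1N1CCN(CCCCCN2C(=O)c3ccccc3S2(=O)=O)CC1`, gives 125 nM in an assay on HEK293 cells for displacement of a labelled ligand from 5-hydroxytryptamine receptor 7 (Homo sapiens); a lower number here means a stronger inhibitor, a higher number a weaker inhibitor.
Compound 2, `COc1ccccc1N1CCN(CCCCCCN2C(=O)c3ccccc3S2(=O)=O)CC1`, gives 105 nM in this assay.

Of the two numbers in this assay, compound 1 carries the higher one, but compound 2 lies within the scatter of it, so the two cannot be told apart on this evidence. Compound 3, `O=C1c2ccccc2S(=O)(=O)N1CCCCCN1CCN(c2cccc3ccccc23)CC1`, has not yet been measured. It differs from compound 1 in one place: naphthalen-1-yl in place of 2-methoxyphenyl on an amine nitrogen in a ring. Going by the values given here, no measured pair shows the effect of such an exchange on the shared core, and the two measured compounds differ from each other only in the linking chain, which gives no guide to it. Compound 3 is therefore expected to land near compound 1, if anything a little lower, with the step of a 1.6-fold lower number from compound 1 to compound 3 (0.19 log units; within the scatter) expected to be modest and not clearly beyond the scatter. The estimate for compound 3 is 80 nM, within the range 25 nM to 250 nM.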

Compound 3, inhibition constant: 36 nM
Beside the measured number, compound 3's estimate is 2.2-fold (0.35 log units) above it; low and high end bracket the measured number.
By their numbers in this assay, from the lowest: compound 3; then compounds 2 and 1 (each within the scatter of the next).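

Exchanging 2-methoxyphenyl for naphthalen-1-yl on the ring nitrogen gives a 3.5-fold lower number from compound 1 to compound 3 (0.54 log units; beyond the scatter) in this assay, so this position responds to the group it carries, a change that lies beyond the scatter, unlike the difference in linking chain between the two earlier compounds. The position accepts the loss of the hydrogen-bond acceptor of 2-methoxyphenyl together with the entry of a second six-membered aromatic ring, and the number falls rather than rises. Going by these compounds alone, nothing available explains the step, and the single pair cannot separate the contribution of the lost acceptor from that of the added ring.

Going by these compounds, it remains open whether a plain phenyl, a naphthalen-2-yl or a quinolinyl group on the same nitrogen would give a similar number. Also open, on these data alone, is whether naphthalen-1-yl brings a comparable step on the linking chain of compound 2.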